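A Ring Nitrogen Enters the Aryl Group of Compound 1

The source may report more compounds than this note shows. Statements on the series, on what has been measured and on what is new or still open speak of the compounds shown alone.

Three ureas built on the shared core have been measured in an assay on isolated protein for displacement of a labelled ligand from acyl-CoA:cholesterol acyltransferase (Oryctolagus cuniculus); on this read-out higher numbers stand for weaker inhibition and lower numbers for stronger inhibition. Compound 1 `CC(C)c1cccc(C(C)C)c1NC(=O)Nc1nc2ccccc2n1-c1cccc(Cl)c1` gives 20 nM, the second highest of the three numbers. Compound 3 `CC(C)c1cccc(C(C)C)c1NC(=O)Nc1nc2ccccc2n1-c1c(Cl)cccc1Cl` gives 11 nM, and compound 2 `CC(C)c1cccc(C(C)C)c1NC(=O)Nc1nc2ccccc2n1-c1ccccc1C(F)(F)F` gives 72 nM. The step of a 1.8-fold lower number from compound 1 to compound 3 (0.26 log units; within the scatter) lies within the scatter, whereas a 3.6-fold higher number from compound 1 to compound 2 (0.56 log units; beyond the scatter) lies beyond it; between the two outer compounds the step is a 6.5-fold lower number from compound 2 to compound 3 (0.82 log units; beyond the scatter).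

Compound 4 `CC(C)c1cccc(C(C)C)c1NC(=O)Nc1nc2ccccc2n1-c1ncccc1Cl` differs from compound 1 in one place: 3-chloropyridin-2-yl in place of 3-chlorophenyl on an aromatic nitrogen. Going by the values given here, none of the measured steps tests such a change, since the steps from compound 1 to compound 2 and from compound 1 to compound 3 exchange one carbon-only ring for another carbon-only ring. Those steps do show that changing the ring on the aromatic nitrogen moves this assay by a modest amount in either direction, or not beyond the scatter. The step expected from this change is a 1.8-fold higher number from compound 1 to compound 4 (0.24 log units; within the scatter). The estimated value for compound 4 in this assay is 35 nM, with a range from 10 nM to 120 nM.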

Compound 4, half-maximal inhibitory concentration: 100 nM
Estimate against measurement, compound 4: 2.9-fold (0.46 log units) below; the measured number falls inside the stated range.
By their numbers in this assay, from the lowest: compounds 3 and 1 (each within the scatter of the next); then compounds 2 and 4 (each within the scatter of the next).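

Going by these compounds alone, the move to compound 4 is the first here to put a ring with 1 hetero atom and 1 hydrogen-bond acceptor on the aromatic nitrogen, and it brings a 5.0-fold higher number from compound 1 to compound 4 (0.70 log units; beyond the scatter) in this assay. Against the other rings, the same group gives a 9.1-fold higher number from compound 3 to compound 4 (0.96 log units; beyond the scatter) but only a 1.4-fold higher number from compound 2 to compound 4 (0.14 log units; within the scatter), which places compound 4 with compound 2 at the high end of the numbers and apart from compound 1 and compound 3. No measurement at hand explains this change.

The compounds shown do not separate the effect of the ring nitrogen from that of the chlorine, which stands at a different place in 3-chloropyridin-2-yl than in 3-chlorophenyl. They also leave open how an amine or a methoxy group on the 3-chloropyridin-2-yl ring would read in this assay.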